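From a Hexyl Chain to a Cyclohexyl Ring

A few compounds are considered here, and "the series" means these few. Any claim that something is new, unique, unknown or untested is made for them only; others in the source may bear on it.

In a functional assay on brain (Rattus norvegicus, strain Wistar) for inhibition (on this read-out higher numbers stand for weaker inhibition and lower numbers for stronger inhibition), compound 1 `COc1ccc(-c2c(C)[nH]c(=O)n2C2CCCCC2)cc1` gives 20400 nM, and compound 2 `CCCCCCc1ccc(-c2c(C)[nH]c(=O)n2C2CCCCC2)cc1` gives 13700 nM. Within the data shown here, these are the only two numbers available, and they lie within the usual scatter of each other, so compound 2 stands level with compound 1. Compound 3 `Cc1[nH]c(=O)n(C2CCCCC2)c1-c1ccc(C2CCCCC2)cc1` keeps the shared core and differs from compound 2 in one group, with cyclohexyl in place of hexyl on an aromatic carbon. Among the measured compounds shown here, only one measured step bears on this change, and it involves a different pair of groups: a 1.5-fold lower number from compound 1 to compound 2 (0.17 log units; within the scatter). For the measured compounds named here, no measured compound yet shows what a ring does at this carbon, so the data offer no direction. Going by the values given here, with a 1.5-fold lower number from compound 1 to compound 2 (0.17 log units; within the scatter) as the only guide, no step beyond the scatter is expected in this assay. The estimated step is a 1.0-fold higher number from compound 2 to compound 3 (0.01 log units; within the scatter). Compound 3 is expected at 14000 nM, with an estimated range of 6000 nM to 32000 nM.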

Compound 3, half-maximal inhibitory concentration: 28900 nM
The estimate for compound 3 lay 2.1-fold (0.31 log units) below the measured number, and the stated range covers the measured number.
By their numbers in this assay, from the lowest: compounds 2, 1 and 3 (each within the scatter of the next, the first and the last beyond it).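

Among these compounds, replacing the open hexyl chain with a cyclohexyl ring gives the first step at this aromatic carbon that clears the scatter in this assay: a 2.1-fold higher number from compound 2 to compound 3 (0.32 log units; beyond the scatter). Both groups carry 6 heavy atoms, all carbon, so they are not fully interchangeable here even at equal atom count, although the step is modest. The comparison with methoxy gives a 1.4-fold higher number from compound 1 to compound 3 (0.15 log units; within the scatter), which leaves compound 3 level with compound 1, and no measurement is available to explain why the ring and the chain differ.

As far as these compounds go, whether a longer chain, a smaller ring such as cyclopentyl, or an amine or carboxylic acid at this carbon would move the number well beyond the scatter remains open. Also open, from the compounds shown here alone, is whether the cyclohexyl on the shared core responds to change in the same way.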